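Sulfonamide series: lipophilicity ahead of an ethylphenyl analogue

The compounds below may be only part of what the source reports. "The series", "measured", "known", "first", "only" and "open" are said of these compounds alone.

Among the compounds with values here, compound 2 `CC(C)CN(c1cccc(F)c1)S(=O)(=O)c1ccc2c(c1)C(=O)CC(C1CCOCC1)O2` gives 3.5 in a physicochemical assay for lipophilicity, at pH 7.4 (a higher number here means a more lipophilic compound, a lower number a more polar compound), the highest of the two numbers measured so far. Within the data shown here, compound 1 `CCc1ccc(N(CC(C)C)S(=O)(=O)c2ccc3cc(OCC4CCOCC4)c(C(=O)O)cc3c2)cc1` gives 1.77 in this assay, a value that sits beyond the scatter under that of compound 2; no single-change step connects these two compounds, so only the two values themselves are known. Compound 3 `CCc1ccc(N(CC(C)C)S(=O)(=O)c2ccc3c(c2)C(=O)CC(C2CCOCC2)O3)cc1` has not been measured. It differs from compound 2 in one place: 4-ethylphenyl in place of 3-fluorophenyl on a sulfonamide nitrogen. For compound 3 in this assay an upward step beyond the scatter is expected, a number 0.70 log units higher from compound 2 to compound 3 (beyond the scatter). Compound 3 is estimated at 4.2, within 3.7 to 4.7.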

Compound 3, distribution coefficient: 4.21
The estimate for compound 3 lay 0.01 log units below the measured number; measured number inside the range.
By their numbers in this assay, from the lowest: compound 1; then compound 2; then compound 3.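

Within the data shown here, with the shared core held constant, this is the first single-change reading at the sulfonamide nitrogen: in this assay, 4-ethylphenyl in place of 3-fluorophenyl gives a number 0.71 log units higher from compound 2 to compound 3 (beyond the scatter). No available evidence accounts for this step. Among these compounds, the single swap changes both the substituent and its printed name position, so the ethyl and fluorine contributions cannot be separated. On these data alone, an unsubstituted phenyl, or a phenyl carrying an amine or a carboxylic acid, on this nitrogen remains open, as does whether the step would hold on another core.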